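Trimethoxychalcones and a single hydroxy change

The source may hold more compounds than are shown below. What is called first, only, known or untested is meant among the compounds shown, and "the series" means these compounds.

Three compounds share one core and differ only in the ring on the double-bonded chain carbon. Compound 1 `COc1cccc(/C=C/C(=O)c2c(OC)cc(OC)cc2OC)c1` gives 37% in a functional assay on NCI-H727 cells (Homo sapiens), read by fluorescence and BrdU incorporation, with a stated time of 48 h, tested at 10 uM; on this read-out higher numbers stand for a weaker effect at the one concentration tested and lower numbers for a stronger effect; compound 2 `COc1cc(OC)c(C(=O)/C=C/c2ccc(F)cc2)c(OC)c1` gives 31%, and compound 3 `COc1cc(OC)c(C(=O)/C=C/c2ccc(Br)cc2)c(OC)c1` gives 39%. Within the data shown here, compound 1 stands second highest of the three, with compound 3 nearest and compound 2 furthest; all three steps, a number 6 percentage points lower from compound 1 to compound 2 (within the scatter), a number 2 percentage points higher from compound 1 to compound 3 (within the scatter) and a number 8 percentage points higher from compound 2 to compound 3 (within the scatter), stay within the scatter, so the measured set shows no compound apart from the others.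

Compound 4 `COc1cccc(/C=C/C(=O)c2c(O)cc(OC)cc2OC)c1` differs from compound 1 by hydrogen in place of methyl on an oxygen on an aromatic ring. Among the measured compounds shown here, none of the measured steps touches this oxygen on the core; all three alter the other ring and all are within the scatter. The data give nothing that points to a change beyond the scatter for this kind of alteration, so the expected step is no change at the digits printed from compound 1 to compound 4 (within the scatter), with no direction favoured. Compound 4 is therefore estimated at 37%, between 20% and 55%.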

Compound 4, a percentage reported as activity, at one concentration (the size of the read-out at that concentration, not a potency): 35%
Beside the measured number, compound 4's estimate is 2 percentage points above it; low and high end bracket the measured number.
By their numbers in this assay, from the lowest: compounds 2, 4, 1 and 3 (each within the scatter of the next).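

Hydroxy in place of methoxy on an aromatic ring of the shared core gives a number 2 percentage points lower from compound 1 to compound 4 (within the scatter) in this assay, the first change shown on the core rather than on the other ring. At this oxygen, then, hydrogen and methyl are not separated on this read-out, and a change on the core stays within the scatter just as the changes on the other ring do. Nothing available here speaks to the reason for this.

The compounds shown leave open whether a longer chain or a carboxylic acid on this oxygen, or an amine in its place, would move the number beyond the scatter. They also leave open whether the same change at either of the other methoxy groups on the core would read alike.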